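This account rests on a few compounds, and the source may have more. Where it says the series, first, only, none or still open, it means among the compounds named here.

Compound 1 `N#CCOc1ccc2c(c1)CCc1c-2c2c(c3c4ccccc4n(CCO)c13)CNC2=O`: 8%
Compound 2 `O=C1NCc2c1c1c(c3c2c2ccccc2n3CCO)CCc2cc(OCCO)ccc2-1`: 46%
Compound 3 `N#CCCCOc1ccc2c(c1)CCc1c-2c2c(c3c4ccccc4n(CCO)c13)CNC2=O`: 46%

In an assay on isolated protein for inhibition of mitogen-activated protein kinase kinase kinase 11 (Homo sapiens), tested at 1 uM (a higher number here means more inhibition at the concentration tested (going by the name of the read-out), a lower number less inhibition), compound 3 gives 46%, level with compound 2 at the digits printed, the two together the highest of the three; the step of no change at the digits printed from compound 2 to compound 3 (within the scatter) is within the scatter, while a number 38 percentage points higher from compound 1 to compound 3 (beyond the scatter) is a large step beyond it. Compound 4 `O=C1NCc2c1c1c(c3c2c2ccccc2n3CCO)CCc2cc(OCC3CC3)ccc2-1` differs from compound 3 by cyclopropyl in place of 2-cyanoethyl on a saturated chain carbon bound to an oxygen on an aromatic ring. Among the measured compounds shown here, two steps bear on this place: a number 38 percentage points higher from compound 1 to compound 2 (beyond the scatter) and a number 38 percentage points higher from compound 1 to compound 3 (beyond the scatter) were both large, whereas no change at the digits printed from compound 2 to compound 3 (within the scatter) showed that exchanging one larger group for another at this chain changes nothing beyond the scatter. Compound 4 is therefore expected to stay close, with a number 4 percentage points lower from compound 3 to compound 4 (within the scatter), giving an estimate of 42% within 22% to 60%.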

Compound 4, a percentage reported as inhibition, at one concentration (the size of the read-out at that concentration, not a potency): 32%
For compound 4 the middle estimate is 10 percentage points above the measured one; the range from low to high includes it.
By their numbers in this assay, from the lowest: compound 1; then compound 4; then compounds 2 and 3 (each within the scatter of the next).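

In this assay, the number at this place on a saturated chain carbon bound to an oxygen on an aromatic ring turns out lower than the earlier level pair suggested: cyclopropyl gives a number 14 percentage points lower from compound 3 to compound 4 (beyond the scatter) and also a number 14 percentage points lower from compound 2 to compound 4 (beyond the scatter). Even so, the cyclopropyl group keeps a clear gain over cyano, with a number 24 percentage points higher from compound 1 to compound 4 (beyond the scatter). Nothing available explains this order of groups.

Going by these compounds, whether an amine, a carboxylic acid or a cyclohexyl ring at this place would reach the level of compound 2 and compound 3 remains open.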